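Extending the ester chain: compound 2 to compound 3

The source may report more compounds than this note shows. Statements on the series, on what has been measured and on what is new or still open speak of the compounds shown alone.

Of the compounds shown here, two have numbers so far. Compound 1 `COC(=O)C1=C(C)NC(C)=C(C(=O)OC)C1c1cnc(SC)n1Nc1ccccc1` gives 3.54 nM in an assay on isolated protein (strain albino) for antagonist activity at Voltage-dependent L-type calcium channel subunit alpha-1C (Cavia porcellus); a lower number here means a stronger inhibitor, a higher number a weaker inhibitor. Compound 2 `CCOC(=O)C1=C(C)NC(C)=C(C(=O)OC)C1c1cnc(SC)n1Nc1ccccc1` carries an ethyl ester where compound 1 has a methyl ester; in this assay compound 2 gives 1.66 nM. Among the measured compounds shown here, the one step between them, a 2.1-fold lower number from compound 1 to compound 2 (0.33 log units; beyond the scatter), is the only measured step in the set. Compound 2 thus holds the lowest of the two numbers, with compound 1 as its nearest neighbour.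

Compound 3 `COCCOC(=O)C1=C(C)NC(C)=C(C(=O)OC)C1c1cnc(SC)n1Nc1ccccc1` is not yet measured. It differs from compound 2 by methoxy in place of hydrogen on a saturated chain carbon, two bonds along the chain from an oxygen next to a carbonyl group; cut one bond further out, the ethyl ester of compound 2 becomes a 2-methoxyethyl ester. For the measured compounds named here, the only step that bears on this is a 2.1-fold lower number from compound 1 to compound 2 (0.33 log units; beyond the scatter), a modest lowering when the ester chain grew by one carbon. That step concerned a methyl, not a methoxy placed two bonds along the chain, so it bears only loosely on compound 3. The expectation is therefore a step of about a 1.2-fold lower number from compound 2 to compound 3 (0.07 log units; within the scatter) in this assay, not beyond the scatter. Compound 3 is estimated at 1.4 nM, within 0.4 nM to 4.5 nM.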

Compound 3, half-maximal inhibitory concentration: 9.65 nM
Beside the measured number, compound 3's estimate is 6.9-fold (0.84 log units) below it; the measured number lies above the stated range.
By their numbers in this assay, from the lowest: compound 2; then compound 1; then compound 3.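

In this assay the ester chain does not follow a single direction as it grows: the lowering seen in a 2.1-fold lower number from compound 1 to compound 2 (0.33 log units; beyond the scatter) does not carry on to the 2-methoxyethyl ester, which instead gives a 5.8-fold higher number from compound 2 to compound 3 (0.76 log units; beyond the scatter) and so runs the opposite way. Methoxy in place of hydrogen on the saturated chain carbon, two bonds along the chain from an oxygen next to a carbonyl group, more than cancels the earlier gain, as the comparison with the methyl ester shows in a 2.7-fold higher number from compound 1 to compound 3 (0.44 log units; beyond the scatter) and leaves compound 3 with the highest number of the three. No measurement at hand explains this reversal, and the three compounds record only its direction and size.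

As far as these compounds go, it remains open whether the rise in the number goes with the ether oxygen itself or with the length of the chain, a question that a straight propyl or butyl ester would address. Also open, from the compounds shown here alone, is how the same position behaves with a 2-hydroxyethyl or 2-aminoethyl ester, or with a branched isopropyl ester, set against the ethyl ester of compound 2.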